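A few compounds are considered here, and "the series" means these few. Any claim that something is new, unique, unknown or untested is made for them only; others in the source may bear on it.

Measured compounds: compound 1 `C=C1CC[C@H]2C(C)(C)CCC[C@]2(C)[C@H]1C/C=C1/C(=O)OC[C@H]1O` with 95.6%; compound 2 `C=C1CC[C@H]2C(C)(C)CCC[C@]2(C)[C@H]1C/C=C1\C=COC1=O` with 97.7%.

In an ADME assay on RAW264.7 cells (Mus musculus) for cytotoxicity, read by luminescence and CellTiter-Glo, with a stated time of 18 h, tested at 1 uM (on this read-out higher numbers stand for a weaker effect at the one concentration tested and lower numbers for a stronger effect), compound 1 gives 95.6%, the lower of the two numbers shown, with compound 2 at 97.7%, a gap within the scatter. Both values sit near the top of the scale. Compound 3 `C=C1CC[C@H]2C(C)(C)CCC[C@]2(C)[C@H]1C/C=C1\C(=O)OC[C@H]1O` differs from compound 1 in configuration only: the two compounds have the same atoms and bonds and differ only in configuration as drawn: 1 of 5 stereo elements differ; a double bond is drawn E in compound 1 and Z in compound 3. Among the compounds with values here, no measured pair shows what such a change does in this assay, so the expected step of a number 0.4 percentage points higher from compound 1 to compound 3 (within the scatter) is none beyond the scatter. Compound 3 is estimated at 96%, from 86% to 102%.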

Compound 3, a percentage reported as activity, at one concentration (the size of the read-out at that concentration, not a potency): 95.5%
The estimate for compound 3 lay 0.5 percentage points above the measured number, within the range that was stated.
By their numbers in this assay, from the lowest: compounds 3, 1 and 2 (each within the scatter of the next).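

Within the data shown here, the only measured pair in this assay that differs in one place turns on the geometry of a double bond, and reversing it gives a number 0.1 percentage points lower from compound 1 to compound 3 (within the scatter). At the one concentration tested, drawing this double bond E or Z therefore makes no difference beyond the scatter. The comparison isolates that single change because nothing else varies: the fact that compounds 1 and 3 differ only in the configuration as drawn.

The compounds shown leave open whether an amine or a carboxylic acid in place of the hydroxyl group would shift the read-out. They also leave open whether the two geometries stay alike at other concentrations.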